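The source may hold more compounds than are shown below. What is called first, only, known or untested is meant among the compounds shown, and "the series" means these compounds.

Compound 1 `CSc1nc(-c2ccccc2)c(C#N)c(N2CCN(c3ccnc4cc(Cl)ccc34)CC2)n1` is the starting point. In an ADME assay on Vero cells (Chlorocebus sabaeus) for cytotoxicity, read by microscopy (a lower number here means that less compound is tolerated, a higher number that more compound is tolerated), compound 1 gives only a limit, > 100000 nM; this is the limit of > 100000 nM in this assay, at which 1 of the 3 values shown sits. Compound 2 `CSc1nc(NCCCCNc2ccnc3cc(Cl)ccc23)c(C#N)c(-c2cccc([N+](=O)[O-])c2)n1` gives 20000 nM in this assay. Compound 3 `CSc1nc(NCCCCNc2ccnc3cc(Cl)ccc23)c(C#N)c(-c2ccc([N+](=O)[O-])cc2)n1` gives 4000 nM. The step of a 5.0-fold lower number from compound 2 to compound 3 (0.70 log units; beyond the scatter) changes the position of a nitro group rather than introducing one, so it bears only indirectly on compound 4 `CSc1nc(-c2ccc([N+](=O)[O-])cc2)c(C#N)c(N2CCN(c3ccnc4cc(Cl)ccc34)CC2)n1`, which differs from compound 1 by nitro in place of hydrogen on an aromatic carbon. Going by the values given here, no measured step puts a nitro group onto a plain phenyl. Because compound 3, which carries the 4-nitrophenyl, sits at 4000 nM, a lower number is expected. Compound 4 is estimated at 40000 nM, between 8000 nM and 200000 nM, which would mean an at least 2.5-fold lower number from compound 1 to compound 4 (0.39 log units; beyond the scatter).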

Compound 4, minimum cytotoxic concentration: 100000 nM
The estimate for compound 4 lay 2.5-fold (0.40 log units) below the measured number, and the stated range covers the measured number.
By their numbers in this assay, from the lowest: compound 3; then compound 2; then compound 4.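

On the shared core, the change from phenyl to 4-nitrophenyl can now be read directly in this assay, and it gives a number no higher from compound 1 to compound 4 (the limit leaves the size open). With the nitro group in place, compound 4 gives 100000 nM, a measured number. Compound 1 gives only a limit, so the size of this step cannot be read: the limit of > 100000 nM in this assay, at which 1 of the 4 values shown sits.

The compounds shown leave open whether the nitro group changes the tolerated concentration at all on this core. They also leave open how an amine or a carboxylic acid in that place would read.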